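The source may hold more compounds than are shown below. What is called first, only, known or untested is meant among the compounds shown, and "the series" means these compounds.

Compound 1 `Oc1ccccc1-c1cc(-c2ccsc2)cc(-c2ccccc2O)n1` is tested in a functional assay on HeLa cells (Homo sapiens) for cytotoxicity, read by CCK-8 assay; a lower number here means a stronger inhibitor, a higher number a weaker inhibitor. Here compound 1 gives only a limit, > 50000 nM. Compound 2 `Oc1cccc(-c2cc(-c3ccsc3)cc(-c3ccccc3O)n2)c1` arises from compound 1 by 3-hydroxyphenyl in place of 2-hydroxyphenyl on an aromatic carbon, and compound 2 likewise gives only a limit, > 50000 nM. That move, a step that the two limits leave unreadable from compound 1 to compound 2, cannot be sized because of the limit of > 50000 nM in this assay, at which 3 of the 3 values shown sit. Compound 3 `Oc1ccccc1-c1cc(-c2cccnc2)cc(-c2ccccc2O)n1` differs from compound 1 in its core by pyridin-3-yl in place of thiophen-3-yl on an aromatic carbon; compound 3 too gives only a limit, > 50000 nM. Compound 4 `Oc1cccc(-c2cc(-c3cccnc3)cc(-c3ccccc3O)n2)c1` has not yet been measured and arises from compound 3 by 3-hydroxyphenyl in place of 2-hydroxyphenyl on an aromatic carbon. This is the same kind of change as from compound 1 to compound 2, though the surroundings differ: meta to a pyridin-3-yl group here, meta to a thiophen-3-yl group there. The step from compound 3 to compound 4 is expected to be a step that the limit leaves unreadable from compound 3 to compound 4, resting on compound 3 sitting at > 50000 nM. Compound 4 is estimated at 70000 nM, between 30000 nM and 200000 nM.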

Compound 4, half-maximal inhibitory concentration: 7530 nM
Beside the measured number, compound 4's estimate is 9.3-fold (0.97 log units) above it; the measured number lies below the stated range.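

With the pyridin-3-yl group in place, 3-hydroxyphenyl in place of 2-hydroxyphenyl gives an at least 6.6-fold lower number from compound 3 to compound 4 (0.82 log units; beyond the scatter) in this assay. With 3-hydroxyphenyl in place, pyridin-3-yl in place of thiophen-3-yl gives an at least 6.6-fold lower number from compound 2 to compound 4 (0.82 log units; beyond the scatter), so in this small set the lower number appears only where the two groups occur together. The same hydroxyphenyl change on the core of compound 1 cannot be read, so the data neither show that it carries over to that core nor show that it fails there, and the other steps are unreadable for the same reason, because of this: the limit of > 50000 nM in this assay, at which 3 of the 4 values shown sit.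

As far as these compounds go, both readable steps give only a minimum size, so their true size remains open. Also open, from the compounds shown here alone, is whether an amine in place of the hydroxy group of compound 4 would give a similar number.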